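A few compounds are considered here, and "the series" means these few. Any claim that something is new, unique, unknown or untested is made for them only; others in the source may bear on it.

Compound 1 `C=C1CN(C)/C(=N/c2ccccc2)S1`: > 100000 nM (a limit of the assay, not a number)
Compound 2 `COc1ccc(/C=C2/CN(C)/C(=N/c3ccc(OC)cc3)S2)cc1`: 15900 nM

Both compounds were tested in a functional assay on HCT-116 cells (Homo sapiens) for antiproliferative activity, read by MTT assay, with a stated time of 72 h; on this read-out higher numbers stand for weaker inhibition and lower numbers for stronger inhibition. For the measured compounds named here, compound 2 gives 15900 nM, and this is the only true number available so far. Compound 1 reads > 100000 nM, which is a limit of the assay. Compound 2 therefore has no measured number to be ranked against.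

The next compound, compound 3 `COc1ccc(/C=C2/CN(C)/C(=N/c3ccc(F)cc3)S2)cc1`, has not yet been measured. It differs from compound 2 in a single place: fluoro in place of methoxy on an aromatic carbon. This is fluoro in place of methoxy on an aromatic carbon, para to a large group, so 4-methoxyphenyl becomes 4-fluorophenyl.

Going by the values given here, no measured pair shows what this exchange does in this assay, so the forecast has no direct precedent. The starting point is compound 2 at 15900 nM, and no change beyond the usual scatter is expected. The estimated change is a 1.2-fold lower number from compound 2 to compound 3 (0.09 log units; within the scatter), and this estimate carries wide uncertainty. For compound 3 the expected value is 13000 nM, with an estimated range of 4500 nM to 40000 nM.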

Compound 3, half-maximal inhibitory concentration: 10000 nM
Compound 3: the middle estimate sits 1.3-fold (0.11 log units) above what was measured, within the range that was stated.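

In this assay, the measurement for this exchange of 4-methoxyphenyl for 4-fluorophenyl gives a 1.6-fold lower number from compound 2 to compound 3 (0.20 log units; within the scatter) and so the two compounds cannot be told apart on this read-out. For the compounds shown here, this is the first measured view of this position, an aromatic carbon para to a large group, and it shows that methoxy, with two heavy atoms and a hydrogen-bond acceptor, and fluoro, with one heavy atom and no such acceptor, give results that lie within the usual scatter of each other. This single pair shows no trend, and nothing measured here gives a reason for the size of the step.

The compounds shown leave open whether a group of a different kind at this position, such as an amine or a carboxylic acid, would move the number beyond the scatter. They also leave open whether the other 4-methoxyphenyl group, shared by compound 2 and compound 3, would respond in the same way to an exchange for 4-fluorophenyl.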